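From chloro to trifluoromethyl in compound 1

This account rests on a few compounds, and the source may have more. Where it says the series, first, only, none or still open, it means among the compounds named here.

In a functional assay on MCF7 cells (Homo sapiens) for inhibition, read by CCK-8 assay, with a stated time of 48 h (a higher number here means a weaker inhibitor, a lower number a stronger inhibitor), compound 1 (`COc1cc(-c2ccnc3cc(-c4ccc(Cl)cc4)nn23)cc(OC)c1OC`) gives 2320 nM. This lies within the scatter of compound 2 (`Cn1ccc2cc(-c3cc4nccc(-c5ccc(F)cc5)n4n3)ccc21`) at 4580 nM and well above compound 3 (`COc1cc(-c2ccnc3cc(-c4ccc(C)c(C)c4)nn23)cc(OC)c1OC`) at 26 nM. Compound 4 (`COc1cc(-c2ccnc3cc(-c4ccc(C(F)(F)F)cc4)nn23)cc(OC)c1OC`) carries trifluoromethyl in place of chloro on an aromatic carbon, para to a large group: trifluoromethyl in place of chloro on an aromatic carbon. Among the compounds with values here, the only measured step bearing on this change is an 89-fold lower number from compound 1 to compound 3 (1.95 log units; beyond the scatter), with 3,4-dimethylphenyl in place of 4-chlorophenyl. That step is large, but it is a different replacement and sets no direction here. The expected step in this assay stays within the scatter: a 1.3-fold lower number from compound 1 to compound 4 (0.11 log units; within the scatter). For compound 4 the estimate is 1800 nM, with an expected range of 350 nM to 8000 nM.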

Compound 4, half-maximal inhibitory concentration: 2440 nM
Estimate against measurement, compound 4: 1.4-fold (0.13 log units) below, within the range that was stated.
By their numbers in this assay, from the lowest: compound 3; then compounds 1, 4 and 2 (each within the scatter of the next).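

In this assay, trifluoromethyl in place of chloro gives a 1.1-fold higher number from compound 1 to compound 4 (0.02 log units; within the scatter), so at this position the two groups cannot be told apart. The gap to the 3,4-dimethylphenyl compound remains large, at a 94-fold higher number from compound 3 to compound 4 (1.97 log units; beyond the scatter), which leaves compound 3 apart from both compound 1 and compound 4. No supporting measurement accounts for either step.

Open, from the compounds shown here alone, is whether a single methyl, a methoxy, an amine or a carboxylic acid at this carbon would read with compound 3 or with compound 1 and compound 4. Also open, going by these compounds, is which methyl of the 3,4-dimethylphenyl group in compound 3 carries the large step.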